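Swapping the Ring Substituent on an Acid Ceramidase Carbamate

This account rests on a few compounds, and the source may have more. Where it says the series, first, only, none or still open, it means among the compounds named here.

Measured so far:
Compound 1, `CC(C)CNC(=O)n1c(=O)oc2c(C3CCN(C)CC3)cccc21`: 535 nM
Compound 2, `O=C(NCCCCc1ccccc1)n1c(=O)oc2cc(C3CCOCC3)ccc21`: 68 nM

In an assay on HEK293 cells for inhibition of acid ceramidase (Homo sapiens), read by fluorescence, with stated times of 10 min and 3 h (a higher number here means a weaker inhibitor, a lower number a stronger inhibitor), compound 2 gives 68 nM, the lowest of the two numbers shown. Compound 1 gives 535 nM, a higher number that lies beyond the scatter. Compound 3, `CC(C)N1CCC(c2ccc3c(c2)oc(=O)n3C(=O)NCCCCc2ccccc2)CC1`, differs from compound 2 in one place: 1-isopropylpiperidin-4-yl in place of oxan-4-yl on an aromatic carbon. Going by the values given here, no measured pair carries this change, so the direction rests on judgement alone. Compound 3 is expected to come close to compound 2, with the step of a 1.2-fold lower number from compound 2 to compound 3 (0.09 log units; within the scatter) expected to stay within the scatter. The estimate for compound 3 is 55 nM, in the range 15 nM to 200 nM.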

Compound 3, half-maximal inhibitory concentration: 94 nM
Compound 3: the middle estimate sits 1.7-fold (0.23 log units) below what was measured; low and high end bracket the measured number.
By their numbers in this assay, from the lowest: compounds 2 and 3 (each within the scatter of the next); then compound 1.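

In this assay, 1-isopropylpiperidin-4-yl in place of oxan-4-yl on an aromatic carbon gives a 1.4-fold higher number from compound 2 to compound 3 (0.14 log units; within the scatter). This position therefore accepts a group of 9 heavy atoms with a ring nitrogen as readily as one of 6 with a ring oxygen, and the two compounds cannot be told apart here. Nothing available bears on why these two groups read alike. As far as these compounds go, what a carboxylic acid or an unsubstituted piperidin-4-yl would give on this carbon stays open. So does whether the same swap reads alike with a shorter chain on the shared core.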